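The source may report more compounds than this note shows. Statements on the series, on what has been measured and on what is new or still open speak of the compounds shown alone.

In a functional assay on RAW264.7 cells (Mus musculus) for inhibition, with stated times of 2 h and 24 h (on this read-out higher numbers stand for weaker inhibition and lower numbers for stronger inhibition), compound 1 (`COc1ccc([C@@H]2c3c(OC)cc(OC)cc3/C(=C/c3ccc(Cl)cc3)[C@H]2c2cc(OC)cc(OC)c2)cc1`) gives > 200000 nM as a limit, not a number. Compound 2 (`COc1cc(OC)cc([C@@H]2C(SCc3ccccc3)c3cc(OC)cc(OC)c3[C@H]2c2ccccc2)c1`) gives > 200000 nM as a limit too. Compound 3 (`COc1ccc([C@@H]2c3c(OC)cc(OC)cc3C(SCc3ccccc3)[C@H]2c2cc(OC)cc(OC)c2)cc1`) also gives > 200000 nM as a limit. Compound 2 thus stands with the others at the limit of > 200000 nM in this assay, at which 3 of the 3 values shown sit, and has no exact value. Among the compounds with values here, the only measured step is a step that the two limits leave unreadable from compound 2 to compound 3 and offers no size to carry forward. Compound 4 (`COc1cc(OC)cc([C@@H]2C(C(O)c3ccccc3)c3cc(OC)cc(OC)c3[C@H]2c2ccccc2)c1`) differs from compound 2 by hydroxy(phenyl)methyl in place of benzylsulfanyl on a saturated ring carbon in one place: hydroxy(phenyl)methyl in place of benzylsulfanyl on a saturated ring carbon. Within the data shown here, no step of known size or direction can therefore be expected in this assay. The expected change is a number no higher from compound 2 to compound 4 (the limit leaves the size open) and rests on little evidence. Compound 4 is estimated at 200000 nM with an expected range from 60000 nM to 500000 nM in this estimate.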

Compound 4, half-maximal inhibitory concentration: 21600 nM
The estimate for compound 4 lay 9.3-fold (0.97 log units) above the measured number, outside the stated range (below it).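

At this saturated ring carbon, the group matters: in this assay, hydroxy(phenyl)methyl in place of benzylsulfanyl brings an at least 9.2-fold lower number from compound 2 to compound 4 (0.96 log units; beyond the scatter). The earlier compounds shown here could not show this, as none of them gave an exact number to compare. Compound 4 now gives one, while the others stay at a limit: the limit of > 200000 nM in this assay, at which 3 of the 4 values shown sit.

The compounds shown cannot separate the loss of the sulfur from the gain of the hydroxy group, since both come with this one change. On these data alone, how an amine or a carboxylic acid at this carbon would read also remains open.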